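Methyl-to-chloro exchange on the fused core

The compounds below may be only part of what the source reports. "The series", "measured", "known", "first", "only" and "open" are said of these compounds alone.

Measured so far:
compound 1 `Cc1cccc2c1CC/C2=C\C(=O)NC1CC1`: 64 mg/kg
compound 2 `NC(=O)/C=C1\CCc2c(F)ccc(F)c21`: 89 mg/kg

In a functional assay on the whole organism with Mus musculus as the target, in the rotarod test (on this read-out higher numbers stand for an effect only at larger amounts of compound and lower numbers for an effect already at smaller amounts), compound 1 gives 64 mg/kg. Compound 2 gives 89 mg/kg in this assay, and the two values lie within the scatter of each other, so no ordering follows from them. Compound 3 `O=C(/C=C1\CCc2c(Cl)cccc21)NC1CC1` differs from compound 1 by chloro in place of methyl on an aromatic carbon. Among the compounds with values here, no measured pair tests such an exchange, and the two known values do not separate. The step from methyl to chloro is therefore expected to stay within the scatter, in no firm direction. The estimated change is a 1.1-fold higher number from compound 1 to compound 3 (0.04 log units; within the scatter). Compound 3 is expected to give about 70 mg/kg in this assay, with a range from 35 mg/kg to 140 mg/kg.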

Compound 3, dose for half-maximal effect: 66 mg/kg
For compound 3 the middle estimate is 1.1-fold (0.03 log units) above the measured one; the measured number falls inside the stated range.
By their numbers in this assay, from the lowest: compounds 1, 3 and 2 (each within the scatter of the next).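

In this assay, within the data shown here, chloro in place of methyl on this aromatic carbon gives the first direct exchange at this position, and it reads as a 1.0-fold higher number from compound 1 to compound 3 (0.01 log units; within the scatter), so the two groups cannot be told apart here. The earlier pair offered no such one-place comparison. Nothing measured on either group bears on this result.

Open: whether a methoxy group or an amine on this aromatic carbon would also leave the number within the scatter. Going by these compounds, a longer chain in place of the cyclopropyl on the amide nitrogen is equally open.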